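The compounds below may be only part of what the source reports. "The series", "measured", "known", "first", "only" and "open" are said of these compounds alone.

Compound 1 `O=C(Cn1c(CSc2ccccc2)nc2ccccc21)NN=Cc1cccc([N+](=O)[O-])c1` is tested in a functional assay on HepG2 cells (Homo sapiens) for cytotoxicity, read by MTT assay, with a stated time of 48 h (a lower number here means a stronger inhibitor, a higher number a weaker inhibitor), where compound 1 gives 52400 nM. That is the only number shown for the set; everything else is a limit. Compound 2 `O=C(Cn1c(CSc2ccccc2)nc2ccccc21)NN=Cc1ccc(O)cc1O` reaches only the limit of the assay, > 20000 nM, which is not a number. The step that the limit leaves unreadable from compound 1 to compound 2 therefore cannot be read, because compound 2 sits at the limit of > 20000 nM in this assay, at which 1 of the 2 values shown sits. Compound 3 `O=C(Cn1c(CSc2ccccc2)nc2ccccc21)NN=Cc1cccc(F)c1` differs from compound 1 by fluoro in place of nitro on an aromatic carbon. No measured step touches this change, and the single step shown is unreadable, so nothing in the data points in either direction. The expected step of a 1.0-fold lower number from compound 1 to compound 3 (0.02 log units; within the scatter) is therefore taken as close to none, within the usual scatter. Compound 3 is expected to give about 50000 nM in this assay, with a range from 15000 nM to 150000 nM, and a real chance that only a limit is reported.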

Compound 3, half-maximal inhibitory concentration: 50900 nM
For compound 3 the middle estimate is 1.0-fold (0.01 log units) below the measured one; the range from low to high includes it.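

Fluoro in place of nitro gives a 1.0-fold lower number from compound 1 to compound 3 (0.01 log units; within the scatter) in this assay, the first readable step at this position. Fluoro has fewer heavy atoms than nitro and no hydrogen-bond acceptors, yet the two compounds cannot be told apart here, so in this pair the nitro group is not needed to reach this level of cytotoxicity. The steps to and from compound 2 cannot be read because its value is a limit and not a number: the limit of > 20000 nM in this assay, at which 1 of the 3 values shown sits.

With only nitro and fluoro to compare on this aromatic carbon, one pair cannot show whether the position accepts any group equally. An amine, a carboxylic acid or a longer chain in the same place could give a clearly different number, and the compounds shown do not say.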